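The compounds below may be only part of what the source reports. "The series", "measured", "known", "first", "only" and "open" are said of these compounds alone.

All the compounds here share one core and differ only in the aromatic group on a carbon with a double bond to nitrogen. In a functional assay on PC-3 cells (Homo sapiens) for cytotoxicity, read by MTT assay, with a stated time of 72 h (a higher number here means a weaker inhibitor, a lower number a stronger inhibitor), compound 3 `COc1cc2ncnc(Nc3ccc(F)c(Cl)c3)c2cc1NC(=O)N/N=C/c1cc(OC)c(OC)c(OC)c1` gives 36500 nM and compound 2 `COc1cc2ncnc(Nc3ccc(F)c(Cl)c3)c2cc1NC(=O)N/N=C/c1cccc(Cl)c1Cl` gives 24400 nM. Among the compounds with values here, these are the only two numbers available, and a 1.5-fold higher number from compound 2 to compound 3 (0.17 log units; within the scatter) shows that they cannot be ranked. Compound 1 `COc1cc2ncnc(Nc3ccc(F)c(Cl)c3)c2cc1NC(=O)N/N=C/c1cccc(Br)c1`, which carries a bromine on its ring, is recorded as "not active" (no number reported), so it cannot be placed on the same scale.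

Compound 4 `COc1cc2ncnc(Nc3ccc(F)c(Cl)c3)c2cc1NC(=O)N/N=C/c1ccc(O)c(Br)c1` has not yet been measured. It has 3-bromo-4-hydroxyphenyl in place of 3,4,5-trimethoxyphenyl (3-bromo-4-hydroxyphenyl in place of 3,4,5-trimethoxyphenyl on a carbon with a double bond to nitrogen). The closest evidence is the swap of one aromatic group for a very different one in a 1.5-fold higher number from compound 2 to compound 3 (0.17 log units; within the scatter), which moved the number by no more than the scatter. Within the data shown here, that is a single step, and no measured compound carries a hydroxyl on this ring, so the support is thin. On that basis, no shift beyond the scatter is expected, and the estimated step is a 1.3-fold lower number from compound 3 to compound 4 (0.10 log units; within the scatter). Compound 1 is a warning that a bromine-bearing compound may yield no number at all. For compound 4, the estimated value is 29000 nM, with an expected range of 12000 nM to 70000 nM.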

Compound 4, half-maximal inhibitory concentration: 15300 nM
Estimate against measurement, compound 4: 1.9-fold (0.28 log units) above; the measured number falls inside the stated range.
By their numbers in this assay, from the lowest: compounds 4, 2 and 3 (each within the scatter of the next, the first and the last beyond it).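

In this assay, within the data shown here, changing the aromatic group on this carbon moves the number beyond the scatter for the first time, with a 2.4-fold lower number from compound 3 to compound 4 (0.38 log units; beyond the scatter), so this position is not indifferent to what it carries, although the step is modest and rests on a single pair. The same 3-bromo-4-hydroxyphenyl group set against 2,3-dichlorophenyl gives a 1.6-fold lower number from compound 2 to compound 4 (0.20 log units; within the scatter), which leaves compound 4 and compound 2 unranked, while a bromine-bearing ring clearly can give a number here, unlike compound 1 with "not active" (no number reported). No measurement is available that explains why the number shifts between these groups.

As far as these compounds go, whether the hydroxyl, the bromine or the two together lie behind the step from 3,4,5-trimethoxyphenyl remains open, as the entering group differs from the leaving one in all its ring substituents at once. Also open, from the compounds shown here alone, is how this assay would read with an amine or a carboxylic acid on the ring, and whether any such group could bring the number well below those seen so far.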